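A few compounds are considered here, and "the series" means these few. Any claim that something is new, unique, unknown or untested is made for them only; others in the source may bear on it.

Measured compounds in an ADME assay on WI-38 cells (Homo sapiens) for cytotoxicity, read by colorimetric assay and crystal violet staining, with a stated time of 24 h; a lower number here means a stronger inhibitor, a higher number a weaker inhibitor:
- compound 1, `COc1ccc(/C=N/NC(=O)c2ccc(-c3cccc(Cl)c3)nc2C)cc1`, 500 ug/mL
- compound 2, `COc1ccc(/C=N/NC(=O)c2ccc(-c3cccc(Cl)c3)nc2C)cc1OC`, 168 ug/mL
- compound 3, `COc1ccc(/C=N/NC(=O)c2ccc(-c3ccc(Cl)cc3)nc2C)cc1`, 500 ug/mL

Compound 1 stands level with compound 3 at the digits given, the two together the highest of the three numbers in this assay; compound 2 is the furthest from it, at a 3.0-fold lower number from compound 1 to compound 2 (0.47 log units; beyond the scatter). The step to compound 3, no change at the digits printed from compound 1 to compound 3 (within the scatter), concerns the chlorophenyl and lies within the scatter.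

Compound 4, `Cc1ccc(/C=N/NC(=O)c2ccc(-c3cccc(Cl)c3)nc2C)cc1`, has not yet been measured. It differs from compound 1 in one place: methyl in place of methoxy on an aromatic carbon. Among the compounds with values here, the methoxy-bearing ring is the ring touched by the step from compound 1 to compound 2, where a second methoxy was added and gave a 3.0-fold lower number from compound 1 to compound 2 (0.47 log units; beyond the scatter); that is the only measured step on this ring, and it adds a group rather than exchanging one, so it bears on compound 4 only loosely. Within the data shown here, no measured step exchanges methoxy for methyl. The expectation for compound 4 is therefore a step of no more than modest size from compound 1, most likely within the scatter, a 1.3-fold lower number from compound 1 to compound 4 (0.10 log units; within the scatter). Compound 4 is estimated at 400 ug/mL in this assay, with a range from 170 ug/mL to 600 ug/mL.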

Compound 4, half-maximal inhibitory concentration: 500 ug/mL
Estimate against measurement, compound 4: 1.3-fold (0.10 log units) below, within the range that was stated.
By their numbers in this assay, from the lowest: compound 2; then compounds 1, 3 and 4 (each within the scatter of the next).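

In this assay, within the data shown here, the change from 4-methoxyphenyl to 4-methylphenyl, with methyl in place of methoxy para to a large group, gives no change at the digits printed from compound 1 to compound 4 (within the scatter) and is the first measured exchange of one group for another on this ring. The oxygen of the methoxy is therefore not required to keep the reading at this place, at least when methyl is the replacement, and two quite similar groups here cannot be told apart in this assay. Among these compounds, the only step on this ring beyond the scatter is still the added methoxy, a 3.0-fold lower number from compound 1 to compound 2 (0.47 log units; beyond the scatter), and the new result gives no reason for the reading staying level, as nothing measured on these compounds accounts for it.

On these data alone, whether an amine, a carboxylic acid or a longer chain such as butoxy at this same place would move the number remains open, since methoxy and methyl span only a narrow choice of groups. As far as these compounds go, it is also open whether the lower number that comes with the added methoxy depends on the methoxy already on the ring, or would appear with methyl there too.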